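A Morpholine Sulfonamide in Place of the Nitroanilide

This account rests on a few compounds, and the source may have more. Where it says the series, first, only, none or still open, it means among the compounds named here.

Compound 1 `CC1(C)C=C(n2ccccc2=O)c2cc(S(=O)(=O)Nc3ccccc3)ccc2O1` and compound 2 `CC1(C)C=C(n2ccccc2=O)c2cc(S(=O)(=O)Nc3ccc([N+](=O)[O-])cc3)ccc2O1` share the same core and were both tested in a functional assay on the whole organism (trachea) with Rattus norvegicus as the target; a lower number here means a smaller maximal response, a higher number a larger maximal response. Compound 1 gave two separate readings, 7.85%; 88% (2 entries), which lie far apart (the several entries of compound 1 in this assay, 7.85%; 88% (2 entries)). Within the data shown here, compound 2 gave 75.6%, the one number available for it, with a further entry that holds no number. Compound 3 `CC1(C)C=C(n2ccccc2=O)c2cc(S(=O)(=O)N3CCOCC3)ccc2O1` has not been measured; it differs from compound 2 by morpholin-4-yl in place of (4-nitrophenyl)amino on a sulfonyl sulfur. Among the measured compounds shown here, no measured pair isolates this change, so the expectation rests on the structural change alone: a downward move beyond the usual scatter is expected, a number 20.6 percentage points lower from compound 2 to compound 3 (beyond the scatter). For compound 3 the largest response is estimated at 55%, with a range from 15% to 95%.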

Compound 3, largest response reached (Emax), in percent of the reference or control that the assay uses: 85.1%
Estimate against measurement, compound 3: 30.1 percentage points below, within the range that was stated.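

In this assay, replacing (4-nitrophenyl)amino with morpholin-4-yl on the sulfonyl sulfur gives a number 9.5 percentage points higher from compound 2 to compound 3 (within the scatter). This position therefore accepts a non-aromatic ring with 0 hydrogen-bond donors without a clear change in the largest response, at least in this one pair. The aromatic ring and nitro group of compound 2 thus appear not to be needed for that response.

On these data alone, whether an open-chain amine such as dimethylamino, or a piperazine ring, would behave alike remains open. Compound 1 offers no firm reference point, as its readings lie far apart: the several entries of compound 1 in this assay, 7.85%; 88% (2 entries)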